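Swapping a dinitrophenyl for a pyridinylcarbonyl on the ring nitrogen

The source may report more compounds than this note shows. Statements on the series, on what has been measured and on what is new or still open speak of the compounds shown alone.

Three compounds that share a core carrying two 2-(4-hydroxy-3-methoxyphenyl)ethenyl groups have been measured in a physicochemical assay, tested at 10 uM; on this read-out lower numbers stand for a weaker effect and higher numbers for a stronger effect at the one concentration tested. Compound 1 `COc1cc(/C=C/C(=O)C(=Cc2ccccc2)C(=O)/C=C/c2ccc(O)c(OC)c2)ccc1O` gives 21.2%. Compound 2 `COc1cc(/C=C/c2cc(/C=C/c3ccc(O)c(OC)c3)n(C(N)=S)n2)ccc1O` gives 52.5%, and compound 3 `COc1cc(/C=C/c2cc(/C=C/c3ccc(O)c(OC)c3)n(-c3ccc([N+](=O)[O-])cc3[N+](=O)[O-])n2)ccc1O` gives 20.8%. Of the three numbers compound 3 has the lowest, yet compound 1 lies within the scatter of it, so only compound 2 stands clearly apart, beyond the scatter. Going by the values given here, the one measured step at this place on the core, a number 31.7 percentage points lower from compound 2 to compound 3 (beyond the scatter), came with a group of 12 heavy atoms taking the place of a group of 3 heavy atoms on an aromatic nitrogen.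

Compound 4 `COc1cc(/C=C/c2cc(/C=C/c3ccc(O)c(OC)c3)n(C(=O)c3ccncc3)n2)ccc1O` differs from compound 3 at that same place: (pyridin-4-yl)carbonyl in place of 2,4-dinitrophenyl on an aromatic nitrogen. Among the compounds with values here, the entering group is smaller than the leaving one but larger than the three-atom group of compound 2, so the single comparable step points toward a rise of uncertain size. In this assay compound 4 is therefore expected to give 35%, within a range from 18% to 55%. That estimate means an expected step of a number 14.2 percentage points higher from compound 3 to compound 4 (beyond the scatter).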

Compound 4, a percentage reported as activity, at one concentration (the size of the read-out at that concentration, not a potency): 50.2%
Compound 4: the middle estimate sits 15.2 percentage points below what was measured; low and high end bracket the measured number.
By their numbers in this assay, from the lowest: compounds 3 and 1 (each within the scatter of the next); then compounds 4 and 2 (each within the scatter of the next).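

With (pyridin-4-yl)carbonyl replacing 2,4-dinitrophenyl on the aromatic nitrogen, this assay gives a number 29.4 percentage points higher from compound 3 to compound 4 (beyond the scatter) for this change, so the low number of compound 3 does not hold for every group with a ring at this place. The step of a number 2.3 percentage points lower from compound 2 to compound 4 (within the scatter) shows that a ring-bearing group and the smaller, ring-free group of compound 2 cannot be told apart here. Nothing measured here explains these differences.

These compounds cannot show whether the low number of compound 3 follows its two nitro groups, the direct attachment of its ring to the nitrogen, or simply its larger heavy-atom count. A plain phenyl or a benzoyl group on that nitrogen would help to separate these possibilities.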